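Swapping the iodine for a nitro group on the benzoyl ring

The compounds below may be only part of what the source reports. "The series", "measured", "known", "first", "only" and "open" are said of these compounds alone.

Compound 1, `O=C(N/N=C/c1cc(I)cc(I)c1O)c1ccccc1`, in a functional assay on HepG2 cells (Homo sapiens) for cytotoxicity, with a stated time of 24 h (a lower number here means a stronger inhibitor, a higher number a weaker inhibitor), gives > 50000 nM, which is a limit of the assay rather than a number.
Compound 2, `O=C(N/N=C/c1cc(I)cc(I)c1O)c1ccc(Cl)cc1`, gives 14800 nM.
Compound 3, `O=C(N/N=C/c1cc(I)cc(I)c1O)c1ccc(I)cc1`, gives 31800 nM.

Compound 3 holds the highest of the two numbers shown in this assay; the one other number lies a step away, a 2.1-fold higher number from compound 2 to compound 3 (0.33 log units; beyond the scatter). Compound 4, `O=C(N/N=C/c1cc(I)cc(I)c1O)c1ccc([N+](=O)[O-])cc1`, differs from compound 3 by nitro in place of iodo on an aromatic carbon. Changes at this same position have so far stayed small: an at least 1.5-fold lower number from compound 1 to compound 3 (0.19 log units; that floor lies within the scatter), an at least 3.3-fold lower number from compound 1 to compound 2 (0.52 log units; beyond the scatter) and a 2.1-fold higher number from compound 2 to compound 3 (0.33 log units; beyond the scatter). From the compounds shown here alone, a nitro group here is untested, so only a modest step in either direction, or none beyond the scatter, is expected in this assay. Compound 4 is therefore estimated at 20000 nM, in the range 6000 nM to 60000 nM, which would be the expected step of a 1.6-fold lower number from compound 3 to compound 4 (0.20 log units; within the scatter).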

Compound 4, half-maximal inhibitory concentration: 24700 nM
The estimate for compound 4 lay 1.2-fold (0.09 log units) below the measured number; the measured number falls inside the stated range.
By their numbers in this assay, from the lowest: compounds 2, 4 and 3 (each within the scatter of the next, the first and the last beyond it). At a limit, above all of these: compound 1.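

In this assay, the nitro group, with its three heavy atoms in place of one, gives a 1.3-fold lower number from compound 3 to compound 4 (0.11 log units; within the scatter) and a 1.7-fold higher number from compound 2 to compound 4 (0.22 log units; within the scatter). Compound 4 therefore cannot be told apart from either halogen compound, although compound 2 and compound 3 differ from each other beyond the scatter. With hydrogen at this place the step is an at least 2.0-fold lower number from compound 1 to compound 4 (0.30 log units; that floor lies within the scatter); this is only a floor, because the value of compound 1 is a limit of the assay and not a number: the limit of > 50000 nM in this assay, at which 1 of the 4 values shown sits.

From the compounds shown here alone, whether an amine, a carboxylic acid or a longer chain at this position would shift the number beyond the scatter stays open.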